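Working notes: from compound 3 to compound 4

A few compounds are considered here, and "the series" means these few. Any claim that something is new, unique, unknown or untested is made for them only; others in the source may bear on it.

Measured in a functional assay on HT-29 cells (Homo sapiens) for cytotoxicity, read by MTT assay, with a stated time of 72 h; a higher number here means a weaker inhibitor, a lower number a stronger inhibitor:
compound 1 `CN(C)CCNc1nc(-c2ccc(NC(=O)Nc3ccc(F)cc3)cc2)nc2ccsc12` gives 350 nM
compound 2 `CN(C)CCNc1nc(-c2ccc(NC(=O)Nc3ccccc3Cl)cc2)nc2ccsc12` gives 310 nM
compound 3 `CN(C)CCNc1nc(-c2ccc(NC(=O)Nc3ccc(Cl)cc3Cl)cc2)nc2ccsc12` gives 1320 nM

Compound 3 carries the highest number of the three: a 3.8-fold higher number from compound 1 to compound 3 (0.58 log units; beyond the scatter) and a 4.3-fold higher number from compound 2 to compound 3 (0.63 log units; beyond the scatter), both beyond the scatter, whereas a 1.1-fold lower number from compound 1 to compound 2 (0.05 log units; within the scatter) is within it.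

Compound 4 `CCN(CC)CCNc1nc(-c2ccc(NC(=O)Nc3ccc(Cl)cc3Cl)cc2)nc2ccsc12` differs from compound 3 only in that (diethylamino in place of dimethylamino on a saturated chain carbon, two bonds along the chain from a nitrogen on an aromatic ring). None of the three measured steps touches this part of the shared core; each of them changes the aryl group on the amide-type nitrogen, and the chain is the same in compounds 1, 2 and 3. Among the measured compounds shown here, there is therefore no measured step that bears on this change, and no step beyond the scatter is expected in this assay: a 1.0-fold lower number from compound 3 to compound 4 (0.01 log units; within the scatter). Compound 4 is thus estimated at 1300 nM, with a range from 500 nM to 3500 nM.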

Compound 4, half-maximal inhibitory concentration: 1940 nM
Compound 4: the middle estimate sits 1.5-fold (0.17 log units) below what was measured; low and high end bracket the measured number.
By their numbers in this assay, from the lowest: compounds 2 and 1 (each within the scatter of the next); then compounds 3 and 4 (each within the scatter of the next).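

Diethylamino in place of dimethylamino gives a 1.5-fold higher number from compound 3 to compound 4 (0.17 log units; within the scatter) in this assay and is the first reading at this end of the chain. Compound 3 and compound 4 cannot be told apart here, so the chain end accepts this change while the 2,4-dichlorophenyl group stays in place. No evidence on why bears on this result.

Open, going by these compounds, is whether a ring amine such as morpholine or piperidine, or a longer chain between the two nitrogens, would also stay within the scatter. Also open, on these data alone, is whether diethylamino reads the same alongside 4-fluorophenyl or 2-chlorophenyl.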